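Pyrazolyl for ethoxy on the acyl-urea aryl ring

The source may hold more compounds than are shown below. What is called first, only, known or untested is meant among the compounds shown, and "the series" means these compounds.

Measured so far in an assay on HEK293 cells for displacement of a labelled ligand from growth hormone secretagogue receptor type 1 (Homo sapiens), with a stated time of 60 min; on this read-out lower numbers stand for stronger inhibition and higher numbers for weaker inhibition:
compound 1 `CCOc1ccc(Cl)c(C(=O)NC(=O)Nc2nc3ccc(S(=O)(=O)CCCN4CCN(C)CC4)cc3s2)c1` gives 0.31 nM
compound 2 `CN1CCC(S(=O)(=O)c2ccc3nc(NC(=O)NC(=O)c4cc5c(cc4Cl)CCN5C)sc3c2)CC1` gives 7.2 nM
compound 3 `CN1CCC(S(=O)(=O)c2ccc3nc(NC(=O)NC(=O)c4cc(N5CCCC5)c(C#N)cc4Cl)sc3c2)CC1` gives 0.4 nM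

Compound 1 and compound 3 sit within the scatter of each other; compound 2 lies beyond it, with a higher number. Compound 4 `CN1CCN(CCCS(=O)(=O)c2ccc3nc(NC(=O)NC(=O)c4cc(-n5cccn5)ccc4Cl)sc3c2)CC1` keeps the core of compound 1 and changes one group on the aryl ring: 1H-pyrazol-1-yl in place of ethoxy on an aromatic carbon. Among the compounds with values here, no single-point step between measured compounds is available, so the size of this step rests on the change alone. Compound 3, carrying different substitution on the same ring, stays close to compound 1, which argues for a small effect. Compound 4 is expected to give a number close to that of compound 1, with a 1.9-fold higher number from compound 1 to compound 4 (0.29 log units; within the scatter) expected to lie within the scatter. The estimate for compound 4 in this assay is 0.6 nM, with a range of 0.15 nM to 2.5 nM.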

Compound 4, half-maximal inhibitory concentration: 0.67 nM
Compound 4: middle estimate off by 1.1-fold (0.05 log units), on the low side, and the stated range covers the measured number.
By their numbers in this assay, from the lowest: compounds 1, 3 and 4 (each within the scatter of the next, the first and the last beyond it); then compound 2.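

Within the data shown here, at this position, para to a chloro group, the change gives the first single-place reading in this assay: a 2.2-fold higher number from compound 1 to compound 4 (0.33 log units; beyond the scatter), a modest step. The ethoxy chain can thus be replaced by a five-membered aromatic ring with 2 hetero atoms at a small cost, with compound 4 at 0.67 nM. No measurement at hand bears on the cause of this step.

On these data alone, how a methoxy group, a dimethylamino group or a carboxylic acid would read at this position remains open. So does whether a 1H-imidazol-1-yl ring would track the 1H-pyrazol-1-yl result.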